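Halogen swap on two lactam cores, cytotoxicity in HOS cells

A few compounds are considered here, and "the series" means these few. Any claim that something is new, unique, unknown or untested is made for them only; others in the source may bear on it.

Two cores carry the same benzyl substituent. Compound 1 `O=C1c2c(ccc(O)c2O)CN1Cc1cccc(Br)c1` and compound 3 `O=C1c2c(ccc(O)c2O)CN1Cc1cccc(I)c1` share one core; compound 2 `O=C1c2ccc(O)c(O)c2C(=O)N1Cc1cccc(Br)c1` and compound 4 `O=C1c2ccc(O)c(O)c2C(=O)N1Cc1cccc(I)c1` share another. The difference between the two cores is not broken down here.

In an ADME assay on HOS cells (Homo sapiens) for cytotoxicity (on this read-out lower numbers stand for stronger inhibition and higher numbers for weaker inhibition), compound 1 gives 7240 nM, compound 3 gives 6920 nM, and compound 2 gives 11400 nM. The three numbers all lie within the scatter of one another, so none is set apart from the others.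

The change from compound 1 to compound 3 is iodo in place of bromo on an aromatic carbon and it made a step of a 1.0-fold lower number from compound 1 to compound 3 (0.02 log units; within the scatter). The change from compound 2 to compound 4 is iodo in place of bromo on an aromatic carbon, the same change at the same place on the other core.

Compound 4 is not yet measured in this assay. Because the measured step of a 1.0-fold lower number from compound 1 to compound 3 (0.02 log units; within the scatter) was flat, the step from compound 2 to compound 4 is expected to be about as flat, a 1.0-fold lower number from compound 2 to compound 4 (0.02 log units; within the scatter). The estimate for compound 4 in this assay is 11000 nM, expected to fall between 5500 nM and 22000 nM.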

Compound 4, half-maximal inhibitory concentration: 12000 nM
Estimate against measurement, compound 4: 1.1-fold (0.04 log units) below; low and high end bracket the measured number.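

In this assay, 3-iodophenyl in place of 3-bromophenyl on the second core gives a 1.1-fold higher number from compound 2 to compound 4 (0.02 log units; within the scatter), so the swap leaves the read-out as flat there as on the first core. Set side by side, the two steps show that the swap carries from one core to the other without a detectable difference: the same change on two cores in this assay, a 1.0-fold lower number (0.02 log units; within the scatter) from compound 1 to compound 3 and a 1.1-fold higher number (0.02 log units; within the scatter) from compound 2 to compound 4, 1.1-fold (0.04 log units) apart, within the scatter of two such steps

Going by these compounds alone, this holds for this one halogen pair, at this one place and in this one cell read-out; with both steps inside the scatter, it shows only that a flat step stayed flat, and it does not show whether a change with a clear effect would also carry between these cores.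

The compounds shown hold only bromo and iodo on the aromatic ring of the benzyl group, so it stays open how an amine, a carboxylic acid or a nitrile at that place would read on either core. Also open, from the compounds shown here alone, is whether the two cores would still track each other with such groups, and what the two hydroxyl groups on each core contribute.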